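The compounds below may be only part of what the source reports. "The series", "measured", "known", "first", "only" and "open" are said of these compounds alone.

Working notes on the series, read in a physicochemical assay for pharmacokinetics; a lower number here means that the compound disappears faster, a higher number that the compound lasts longer. On the shared core, compound 1 (`COc1ccc(CNC(=O)N2C(=O)c3ccccc3S2(=O)=O)cc1`) gives 0.187 h, compound 2 (`O=C(NCc1cccc(Br)c1)N1C(=O)c2ccccc2S1(=O)=O`) gives 0.492 h and compound 3 (`O=C(NCc1ccccc1Cl)N1C(=O)c2ccccc2S1(=O)=O`) gives 0.42 h. Compound 3 therefore belongs to the upper pair of the three, with the gap to its partner inside the scatter: the number shows a 1.2-fold lower number from compound 2 to compound 3 (0.07 log units; within the scatter). Against the remaining compound the reading is a 2.2-fold higher number from compound 1 to compound 3 (0.35 log units; beyond the scatter).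

Next is compound 4 (`O=C(NCc1ccccc1)N1C(=O)c2ccccc2S1(=O)=O`), which has hydrogen in place of chloro on an aromatic carbon, ortho to a large group, so that 2-chlorophenyl becomes phenyl: hydrogen in place of chloro on an aromatic carbon.

Going by the values given here, no measured pair tests this exact change, so the evidence is indirect. The exchange of 3-bromophenyl for 2-chlorophenyl gave only the small step already noted. Among the compounds with values here, the one other step beyond the scatter, a 2.6-fold higher number from compound 1 to compound 2 (0.42 log units; beyond the scatter), also involves 4-methoxyphenyl and was modest. With compound 3 at 0.42 h as the starting point, no shift beyond the scatter is expected in this assay, and the expected step is a 1.2-fold lower number from compound 3 to compound 4 (0.07 log units; within the scatter). Compound 4 is estimated at 0.36 h, with an expected range of 0.19 h to 0.68 h.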

Compound 4, half-life: 1.02 h
Estimate against measurement, compound 4: 2.8-fold (0.45 log units) below; measured number above the stated range.
By their numbers in this assay, from the lowest: compound 1; then compounds 3 and 2 (each within the scatter of the next); then compound 4.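

In this assay, hydrogen in place of chloro on an aromatic carbon, ortho to a large group, gives a step larger than the scatter, a 2.4-fold higher number from compound 3 to compound 4 (0.39 log units; beyond the scatter), so this position is not neutral to the change. The same reading holds for the other two substituents, with a 2.1-fold higher number from compound 2 to compound 4 (0.32 log units; beyond the scatter) and a 5.5-fold higher number from compound 1 to compound 4 (0.74 log units; beyond the scatter), and the plain phenyl therefore stands above all three substituted rings shown, a relation the earlier comparisons among 4-methoxyphenyl, 3-bromophenyl and 2-chlorophenyl could not reveal. The compounds shown offer no measurement that explains this order.

Chloro is tested only in the 2-chlorophenyl group, bromo only in 3-bromophenyl and methoxy only in 4-methoxyphenyl, so the effect of the substituent cannot be separated from that of its place on the ring. As far as these compounds go, it also remains open whether a small group such as fluoro or methyl would stay near the phenyl number, and how a carboxylic acid or an amine on the ring, or a longer chain between the ring and the amide-type nitrogen, would read in this assay.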